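This account rests on a few compounds, and the source may have more. Where it says the series, first, only, none or still open, it means among the compounds named here.

In a functional assay on MCF7 cells (Homo sapiens) for antiproliferative activity, read by MTT assay, with a stated time of 24 h (on this read-out lower numbers stand for stronger inhibition and higher numbers for weaker inhibition), compound 1 `CCCCNC(=O)COc1ccc(C(=O)c2c(CCCC)oc3ccccc23)cc1` reaches only a limit of the assay, > 50000 nM. Compound 2 `CCCCc1oc2ccccc2c1C(=O)c1ccc(OCC(=O)NCc2ccccc2)cc1` gives 19600 nM. Compound 3 `CCCCc1oc2ccccc2c1C(=O)c1ccc(OCCCC(=O)N2CCCC2)cc1` gives 23500 nM, the higher of the two actual numbers, though the gap is small: a 1.2-fold higher number from compound 2 to compound 3 (0.08 log units; within the scatter). Compound 4 `CCCCc1oc2ccccc2c1C(=O)c1ccc(OCCCC(=O)N2CCCCC2)cc1` has piperidin-1-yl in place of pyrrolidin-1-yl on a carbonyl carbon. For the measured compounds named here, no measured step changes this ring alone. The closest evidence is the step just given and an at least 2.1-fold lower number from compound 1 to compound 3 (0.32 log units; beyond the scatter), and each of these replaces the whole amide-bearing group. With so small a swap, no step beyond the scatter is expected in this assay. The expected change is a 1.1-fold lower number from compound 3 to compound 4 (0.05 log units; within the scatter). For compound 4 the estimated value is 21000 nM, within an expected range of 9000 nM to 48000 nM.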

Compound 4, half-maximal inhibitory concentration: 33000 nM
The estimate for compound 4 lay 1.6-fold (0.20 log units) below the measured number; measured number inside the range.
By their numbers in this assay, from the lowest: compounds 2, 3 and 4 (each within the scatter of the next). At a limit, above all of these: compound 1.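

For the compounds shown here, changing pyrrolidin-1-yl to piperidin-1-yl on the carbonyl carbon is the first change to this ring alone, and in this assay it stays within the scatter: a 1.4-fold higher number from compound 3 to compound 4 (0.15 log units; within the scatter). Replacing the whole benzylcarbamoyl group also stays within it: a 1.7-fold higher number from compound 2 to compound 4 (0.23 log units; within the scatter). The last step starts from a limit, not a number: an at least 1.5-fold lower number from compound 1 to compound 4 (0.18 log units; that floor lies within the scatter), a floor that, unlike those for compound 2 and compound 3, does not clear the scatter.

Going by these compounds, whether morpholin-4-yl on the same carbonyl, or a free carboxylic acid in place of the amide, would give a step beyond the scatter remains open.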